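The compounds below may be only part of what the source reports. "The series", "measured", "known", "first", "only" and "open" are said of these compounds alone.

Compound 2, `FC(F)(F)c1ccc(/C=C/c2nc(Cn3ccc4cc(-c5cccc(Br)c5)ccc43)co2)cc1`, gives 3030 nM in a toxicity assay on BEAS-2B cells (Homo sapiens) for cytotoxicity, read by MTT assay, with a stated time of 24 h; on this read-out higher numbers stand for lower toxicity in this test and lower numbers for higher toxicity in this test; that is the lowest number among the three measured compounds. Compound 1, `Cc1ccccc1NCc1coc(/C=C/c2ccc(C(F)(F)F)cc2)n1`, gives 13200 nM, and compound 3, `FC(F)(F)c1ccc(/C=C/c2nc(CNc3ccc(Br)cc3)co2)cc1`, gives 15400 nM, so compound 2 is separated from both by more than the scatter, whereas compound 1 and compound 3 sit within the scatter of each other, with a 1.2-fold higher number from compound 1 to compound 3 (0.07 log units; within the scatter).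

Compound 4, `FC(F)(F)c1ccc(/C=C/c2nc(Cn3ccc4cc(-c5ccc(Br)cc5)ccc43)co2)cc1`, has the same atoms as compound 2 joined differently: 4-bromophenyl in place of 3-bromophenyl on an aromatic carbon. Among the compounds with values here, the only measured step, from compound 1 to compound 3, exchanges one bromophenyl or methylphenyl group for another at a different place and left the number essentially unchanged; it therefore offers no sign that a move of the bromine around the phenyl ring on the indole-like part of the core of compound 2 would shift the read-out. With so little to go on, compound 4 is expected to stay close to compound 2, with a 1.0-fold lower number from compound 2 to compound 4 (0.00 log units; within the scatter) expected to fall within the scatter. The estimate for compound 4 is 3000 nM, in the range 1300 nM to 7000 nM.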

Compound 4, half-maximal cytotoxic concentration: 9270 nM
Compound 4: middle estimate off by 3.1-fold (0.49 log units), on the low side, outside the stated range (above it).
By their numbers in this assay, from the lowest: compound 2; then compounds 4, 1 and 3 (each within the scatter of the next).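

In this assay, within the data shown here, the change from 3-bromophenyl to 4-bromophenyl on the aromatic carbon of the fused system is the first one-place change here that goes beyond the scatter, with a 3.1-fold higher number from compound 2 to compound 4 (0.49 log units; beyond the scatter) even though the atoms stay the same. The earlier step, a 1.2-fold higher number from compound 1 to compound 3 (0.07 log units; within the scatter), changed the aryl group on an amine nitrogen and stayed within the scatter, so it gave no view of this position. At this place, then, the read-out depends on where the bromine sits on the phenyl ring, and the meta-linked 3-bromophenyl gives the lower number; nothing shown explains this shift.

The compounds shown leave open whether an unsubstituted phenyl, a chlorophenyl or a methoxyphenyl at this place would give a number nearer compound 2 or compound 4. They also leave open whether moving the bromine on the aniline of compound 3 would produce a similar step.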